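The source may hold more compounds than are shown below. What is called first, only, known or untested is meant among the compounds shown, and "the series" means these compounds.

The series shares one core, seen in compound 1 `CC(C)N(c1nc(Cl)nc(N[C@H](C)c2ccccc2)n1)C(C)C`, compound 2 `CNc1nc(Cl)nc(N[C@H](C)c2ccccc2)n1` and compound 3 `CCCNc1nc(Cl)nc(N[C@@H](C)c2ccccc2)n1`. In an ADME assay on the whole organism for inhibition, with Oryza sativa as the target, with a stated time of 4 days (a lower number here means a stronger inhibitor, a higher number a weaker inhibitor), compound 1 gives 1620 nM, compound 2 gives 22400 nM, and compound 3 gives 32400 nM, the highest of the three numbers. Compound 3 and compound 2 lie within the scatter of each other, whereas compound 1 sits well below both. For the measured compounds named here, only one single-point step has been measured in this assay: a 14-fold higher number from compound 1 to compound 2 (1.14 log units; beyond the scatter). Compound 4 `CCCN(C)c1nc(Cl)nc(N[C@@H](C)c2ccccc2)n1` has not yet been measured; it differs from compound 3 as follows: methyl in place of hydrogen on a nitrogen on an aromatic ring. That change, propylamino to methyl(propyl)amino, moves toward the diisopropylamino group of compound 1, the reverse of the measured step, which makes a lower number plausible; but the groups are not the same, so that step is only a rough guide. Compound 4 is therefore expected to come in somewhat lower, a 2.7-fold lower number from compound 3 to compound 4 (0.43 log units; beyond the scatter). The estimated value of compound 4 is 12000 nM, in a range from 4000 nM to 40000 nM.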

Compound 4, half-maximal inhibitory concentration: 5500 nM
Estimate against measurement, compound 4: 2.2-fold (0.34 log units) above; the range from low to high includes it.
By their numbers in this assay, from the lowest: compound 1; then compound 4; then compounds 2 and 3 (each within the scatter of the next).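

In this assay, replacing hydrogen with methyl on a nitrogen on an aromatic ring gives a 5.9-fold lower number from compound 3 to compound 4 (0.77 log units; beyond the scatter) on a propylamino compound, so this nitrogen responds to a change of a single carbon and not only to the exchange of a whole group. The step also keeps the propyl chain in place, which the earlier step, a 14-fold higher number from compound 1 to compound 2 (1.14 log units; beyond the scatter) with both nitrogen groups differing, could not do. In both steps, the compound with no hydrogen on this nitrogen has the lower number. The compounds shown leave open whether ethyl or a longer chain such as butyl in place of the new methyl would lower the number further. They also leave open whether a hydroxyl on the propyl chain would be tolerated. No measurement shown here gives a reason for the effect of the methyl group.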